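The source may hold more compounds than are shown below. What is called first, only, known or untested is meant among the compounds shown, and "the series" means these compounds.

Compound 3 `CC[C@H](C)[C@H]1C(=O)N[C@H](Cc2cc(Cl)c(O)c(Cl)c2)C(=O)N[C@@H](C(C)(C)O)C(=O)O[C@H](c2ccccc2)[C@H](C)/C=C/C=C(\C)[C@H](OC)C[C@@H]2O[C@@]2(C)C(=O)N1C` is tested in a functional assay on HCT-116 cells (Homo sapiens) for antiproliferative activity (a lower number here means a stronger inhibitor, a higher number a weaker inhibitor), where compound 3 gives 2.11 nM. That is the lowest of the three numbers measured here, yet its distances to the other two fall within the scatter, so no ordering among them can be claimed. Compound 1 `CC[C@H](C)[C@H]1C(=O)N[C@H](Cc2ccc(O)c(Br)c2)C(=O)N[C@@H](C(C)(C)O)C(=O)O[C@H](c2ccccc2)[C@H](C)/C=C/C=C(\C)[C@H](OC)C/C=C(\C)C(=O)N1C` gives 3.88 nM in this assay, and compound 2 `CC[C@H](C)[C@H]1C(=O)N[C@H](Cc2cc(Cl)c(O)c(Cl)c2)C(=O)N[C@@H](C(C)C)C(=O)O[C@H](c2ccccc2)[C@H](C)/C=C/C=C(\C)[C@H](OC)C[C@@H]2O[C@@]2(C)C(=O)N1C` gives 4.25 nM. Within the data shown here, the only step known between two compounds that differ in one place is a 2.0-fold lower number from compound 2 to compound 3 (0.30 log units; within the scatter), which concerns a hydroxy in place of hydrogen and does not touch the change considered next.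

Compound 4 `CC[C@H](C)[C@H]1C(=O)N[C@H](Cc2ccc(O)c(Br)c2)C(=O)N[C@@H](C(C)(C)O)C(=O)O[C@H](c2ccccc2)[C@H](C)/C=C/C=C(\C)[C@H](OC)C[C@@H]2O[C@@]2(C)C(=O)N1C` differs from compound 3 in one place: 3-bromo-4-hydroxyphenyl in place of 3,5-dichloro-4-hydroxyphenyl on a saturated chain carbon bound to a saturated ring carbon. Compound 1 carries the same 3-bromo-4-hydroxyphenyl group, but it also differs from compound 4 elsewhere in the core, so its value and that of compound 3 can only be set side by side, and they lie within the scatter of each other. Among the measured compounds shown here, no measured step therefore bears directly on this change, and nothing in the data points to a shift beyond the scatter in either direction.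

Compound 4 is accordingly expected to give about 3 nM in this assay, with a range from 1.5 nM to 6 nM, meaning an expected step of a 1.4-fold higher number from compound 3 to compound 4 (0.15 log units; within the scatter).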

Compound 4, half-maximal inhibitory concentration: 1.59 nM
Estimate against measurement, compound 4: 1.9-fold (0.28 log units) above, within the range that was stated.
By their numbers in this assay, from the lowest: compounds 4, 3, 1 and 2 (each within the scatter of the next, the first and the last beyond it).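

In this assay, putting 3-bromo-4-hydroxyphenyl in place of 3,5-dichloro-4-hydroxyphenyl on a saturated chain carbon bound to a saturated ring carbon gives a 1.3-fold lower number from compound 3 to compound 4 (0.12 log units; within the scatter), so this pair shows no measurable difference between the two groups. Among these compounds, this is the first direct reading at this position, where the earlier compounds could only be set side by side: with the rest of the structure held constant, the ring can go from two chlorine atoms to one bromine atom, and from 9 heavy atoms to 8, without a shift beyond the scatter. The swap alters the number of halogen atoms and their kind at the same time, so this single step cannot show what either alteration does alone, and no supporting measurement is available to explain the result.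

How far this position stays open to change is unsettled, since both groups shown carry a halogen and a hydroxy on the phenyl ring. A plain phenyl, or a phenyl ring bearing an amine or a carboxylic acid instead, could show whether this insensitivity extends beyond halogenated 4-hydroxyphenyl groups.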